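The source may report more compounds than this note shows. Statements on the series, on what has been measured and on what is new or still open speak of the compounds shown alone.

Measured compounds:
- compound 1, `COC(=O)c1nc(Br)c2cccnc2c1N[C@H]1CC[C@H](N)CC1`: in a functional assay on HCT-116 cells (Homo sapiens) for cytotoxicity, read by MTT assay, with a stated time of 72 h (a higher number here means a weaker inhibitor, a lower number a stronger inhibitor), compound 1 gives "not determined" (no result reported)
- compound 2, `N[C@H]1CC[C@H](Nc2c(C(=O)NCc3ccc(Cl)cc3Cl)nc(Br)c3cccnc23)CC1`: in this assay compound 2 gives 6000 nM
- compound 3, `N[C@H]1CC[C@H](Nc2c(C(=O)NCc3ccc(F)cc3)nc(Br)c3cccnc23)CC1`: in this assay compound 3 gives 7000 nM

Compound 3 holds the highest of the two numbers available in this assay, but its nearest neighbour, compound 2, sits within the scatter of it, the step being a 1.2-fold higher number from compound 2 to compound 3 (0.07 log units; within the scatter). Compound 1 carries no result, so it gives no footing for comparison.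

Compound 4, `N[C@H]1CC[C@H](Nc2c(C(=O)Nc3ccccc3)nc(Br)c3cccnc23)CC1`, differs from compound 3 by phenyl in place of 4-fluorobenzyl on an amide-type nitrogen. Within the data shown here, the only measured step, a 1.2-fold higher number from compound 2 to compound 3 (0.07 log units; within the scatter), exchanges one aryl group for another on the saturated chain carbon while keeping that chain carbon in place, and it stays within the scatter. Among the measured compounds shown here, no measured step removes the chain carbon or moves from an alkylamide to an anilide, so the present change has no direct precedent among the measured compounds. On the evidence available, the step is expected to be no larger than the scatter, in either direction, with wide uncertainty from the lack of a comparable precedent. The expected step in this assay is a 1.1-fold higher number from compound 3 to compound 4 (0.06 log units; within the scatter). Compound 4 is estimated to give 8000 nM, with a range from 3000 nM to 25000 nM.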

Compound 4, half-maximal inhibitory concentration: 2000 nM
Compound 4: the middle estimate sits 4.0-fold (0.60 log units) above what was measured; measured number outside the range, below it.
By their numbers in this assay, from the lowest: compound 4; then compounds 2 and 3 (each within the scatter of the next).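

In this assay, the group on the amide-type nitrogen now proves able to move the number beyond the scatter: phenyl in place of 4-fluorobenzyl gives a 3.5-fold lower number from compound 3 to compound 4 (0.54 log units; beyond the scatter), and phenyl in place of 2,4-dichlorobenzyl gives a 3.0-fold lower number from compound 2 to compound 4 (0.48 log units; beyond the scatter). Among these compounds, the exchange between the two benzyl groups, a 1.2-fold higher number from compound 2 to compound 3 (0.07 log units; within the scatter), stayed within the scatter, so the anilide of compound 4 is the first change to separate from the others, and it does so by a modest step from either benzyl amide, leaving compound 4 with the lowest number of the three. No measurement in hand accounts for this difference.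

Compound 4 differs from compound 3 both in losing the saturated chain carbon and in losing the ring fluorine, and from compound 2 in losing that carbon and both ring chlorines, so the compounds shown do not tell which of these losses carries the step. An unsubstituted benzyl on the amide nitrogen would separate the two, while a 4-fluorophenyl or 2,4-dichlorophenyl anilide, or a longer chain such as 2-phenylethyl, would test how far the trend extends.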